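Carboxylic acid to primary amide in a leukotriene receptor series

This account rests on a few compounds, and the source may have more. Where it says the series, first, only, none or still open, it means among the compounds named here.

Measured compounds:
compound 1, `CCc1cc(C(C)=O)c(O)cc1OCCCCC(C)(C)C#N`: 79%
compound 2, `CCc1cc(C(C)=O)c(O)cc1OCCCC(C)(C)C(=O)O`: 89%

Both compounds were tested in an assay on isolated protein for inhibition of leukotriene B4 receptor 1 (Homo sapiens), tested at 10 uM; on this read-out higher numbers stand for more inhibition at the one concentration tested (going by the name of the read-out) and lower numbers for less inhibition. Compound 2 gives the higher of the two numbers, but its step from compound 1, a number 10 percentage points higher from compound 1 to compound 2 (within the scatter), is within the scatter, so the two compounds cannot be told apart on this read-out.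

Compound 3, `CCc1cc(C(C)=O)c(O)cc1OCCCC(C)(C)C(N)=O`, has not yet been measured in this assay. It differs from compound 2 only in that (amino in place of hydroxy on a carbonyl carbon). For the measured compounds named here, the one measured step, from compound 1 to compound 2, concerns a different change and is itself within the scatter, so nothing measured here speaks directly to an acid becoming an amide. The expectation for compound 3 is therefore a step of a number 14 percentage points lower from compound 2 to compound 3 (beyond the scatter) relative to compound 2, at the edge of the scatter and no larger. Compound 3 is expected to give about 75% in this assay, within a range of 45% to 95%.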

Compound 3, a percentage reported as inhibition, at one concentration (the size of the read-out at that concentration, not a potency): 92%
Beside the measured number, compound 3's estimate is 17 percentage points below it; low and high end bracket the measured number.
By their numbers in this assay, from the lowest: compounds 1, 2 and 3 (each within the scatter of the next, the first and the last beyond it).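

In this assay, amino in place of hydroxy on the carbonyl carbon gives a number 3 percentage points higher from compound 2 to compound 3 (within the scatter), so the carboxylic acid and the primary amide cannot be told apart at this position, and inhibition at the one concentration tested does not depend on keeping the acid. For the compounds shown here, the change from 2-cyano-2-methylpropyl to 1-carbamoyl-1-methylethyl gives a number 13 percentage points higher from compound 1 to compound 3 (beyond the scatter), the first step in this set to clear the scatter, though only modestly. Nothing measured here explains either step.

On these data alone, because each compound was tested at a single concentration, whether compound 2 and compound 3 differ in potency remains open. Also open, as far as these compounds go, is how a methyl ester, a tetrazole or a hydroxamic acid would read in place of the carbamoyl group.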